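The source may hold more compounds than are shown below. What is called first, only, known or untested is meant among the compounds shown, and "the series" means these compounds.

Of the compounds shown here, three sharing one core have been measured in an ADME assay on NIH3T3 cells (Mus musculus) for cytotoxicity, read by MTT assay, with a stated time of 24 h; on this read-out higher numbers stand for weaker inhibition and lower numbers for stronger inhibition. Compound 1 `O=C(CSc1nnc(-c2ccncc2)o1)N/N=C/c1ccc(O)cc1` gives 158000 nM in this assay; compound 2 `O=C(CSc1nnc(-c2ccncc2)o1)N/N=C/c1cccc(C(F)(F)F)c1` gives 169000 nM, and compound 3 `COc1cccc(/C=N/NC(=O)CSc2nnc(-c3ccncc3)o2)c1` gives 179000 nM. Compound 1 stands apart from compound 2 and from compound 3 only by gaps within the scatter. Compound 4 `O=C(CSc1nnc(-c2ccncc2)o1)N/N=C/c1ccccc1[N+](=O)[O-]` differs from compound 1 by 2-nitrophenyl in place of 4-hydroxyphenyl on a carbon with a double bond to nitrogen. Among the measured compounds shown here, the steps that bear on this change in this assay are a 1.1-fold higher number from compound 1 to compound 3 (0.05 log units; within the scatter) and a 1.1-fold higher number from compound 2 to compound 3 (0.02 log units; within the scatter), both within the scatter, so a change of the group on this carbon is expected to move the number by nothing beyond the scatter. Compound 4 is therefore estimated at 165000 nM in this assay, with a range of 80000 nM to 340000 nM, meaning an expected step of a 1.0-fold higher number from compound 1 to compound 4 (0.02 log units; within the scatter).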

Compound 4, half-maximal inhibitory concentration: 214000 nM
Beside the measured number, compound 4's estimate is 1.3-fold (0.11 log units) below it, within the range that was stated.
By their numbers in this assay, from the lowest: compounds 1, 2, 3 and 4 (each within the scatter of the next).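

Placing 2-nitrophenyl on the carbon with a double bond to nitrogen leaves the number in this assay within the scatter, both against the 4-hydroxyphenyl of compound 1 (a 1.4-fold higher number from compound 1 to compound 4 (0.13 log units; within the scatter)) and against the 3-methoxyphenyl of compound 3 (a 1.2-fold higher number from compound 3 to compound 4 (0.08 log units; within the scatter)). Even a group with no hydrogen-bond donor and more heavy atoms than 4-hydroxyphenyl therefore does not separate from the earlier compounds here. Nothing available explains this flat response.

Going by these compounds, whether an amine or a carboxylic acid on the phenyl ring would move the number remains open. So does the effect of replacing that ring with an open alkyl chain.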